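The source may hold more compounds than are shown below. What is called first, only, known or untested is meant among the compounds shown, and "the series" means these compounds.

Measured in a functional assay on HeLa cells (Homo sapiens) for cytotoxicity, read by MTT assay, with a stated time of 72 h; on this read-out lower numbers stand for stronger inhibition and higher numbers for weaker inhibition (each entry is a limit, not a number):

- compound 1 `CCCS(=O)(=O)Nc1ccc(-c2cn3c(C(=O)OCC)csc3n2)cc1`: > 20000 nM
- compound 2 `CCOC(=O)c1csc2nc(-c3ccc(NS(=O)(=O)c4ccc(C)cc4)cc3)cn12`: > 20000 nM

Compound 2 stands only at a limit, > 20000 nM, so no number places it in this assay. Going by the values given here, the series so far consists of the limit of > 20000 nM in this assay, at which 2 of the 2 values shown sit.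

The next entry is compound 3 `CCOC(=O)c1csc2nc(-c3ccc(NC(=O)CCl)cc3)cn12`, not yet measured. The change is (chloromethyl)carbonyl in place of (4-methylphenyl)sulfonyl on a nitrogen on an aromatic ring.

Among the compounds with values here, the only measured step is a step that the two limits leave unreadable from compound 1 to compound 2. It concerned the group on the sulfonyl sulfur and supplies no size to carry over, whereas the present change replaces the whole (4-methylphenyl)sulfonyl. Within the data shown here, no measured compound carries (chloromethyl)carbonyl, so the direction of any shift in this assay is open.

With only limits to go on, no step beyond the usual scatter is expected, and a further limit is about as likely as a number. The expected change is a number no higher from compound 2 to compound 3 (the limit leaves the size open), and it is a weakly founded expectation. For compound 3 the estimate is 20000 nM, with an expected range from 6000 nM to 60000 nM.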

Compound 3, half-maximal inhibitory concentration: > 20000 nM
Compound 3 gave a limit, no number; the forecaster's own chance of this, stated with the estimate: 55%; the middle value sits exactly at the limit.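

Compound 3 gives > 20000 nM, a limit and not a number. Going by these compounds alone, no step among compound 1, compound 2 and compound 3 can be read. The compounds shown leave open what number any of the three would give in this assay, and whether propylsulfonyl, (4-methylphenyl)sulfonyl and (chloromethyl)carbonyl on the nitrogen differ there at all.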